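This account rests on a few compounds, and the source may have more. Where it says the series, first, only, none or still open, it means among the compounds named here.

Measured so far in a functional assay on HepG2 cells (Homo sapiens) for antiproliferative activity, read by MTT assay, with a stated time of 48 h; on this read-out higher numbers stand for weaker inhibition and lower numbers for stronger inhibition:
- compound 1 `CCNC(=O)Nc1nc(-c2ccc(OCC)cc2)c(-c2cc(OC)c(OC)c(OC)c2)s1`: 30.7 nM
- compound 2 `CCOc1ccc(-c2nc(NS(=O)(=O)c3ccccc3C(F)(F)F)sc2-c2cc(OC)c(OC)c(OC)c2)cc1`: > 5000 nM, a limit of the assay
- compound 3 `CCOc1ccc(-c2nc(NS(=O)(=O)c3ccc([N+](=O)[O-])cc3OC)sc2-c2cc(OC)c(OC)c(OC)c2)cc1`: > 5000 nM, a limit of the assay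

Compound 3 has no number, only the limit > 5000 nM. Going by the values given here, the sulfonyl compounds measured so far are known only through (the limit of > 5000 nM in this assay, at which 2 of the 3 values shown sit).

Compound 4 `CCOc1ccc(-c2nc(NS(=O)(=O)c3ccc(OC)c(F)c3)sc2-c2cc(OC)c(OC)c(OC)c2)cc1` changes the group on the sulfonyl sulfur: 3-fluoro-4-methoxyphenyl in place of 2-methoxy-4-nitrophenyl on a sulfonyl sulfur. Among the compounds with values here, the only measured step at this place is a step that the two limits leave unreadable from compound 2 to compound 3, so no size can be carried over from it. Compound 1 gives a number, 30.7 nM, but it has no sulfonyl sulfur and sets no size for this exchange.

In this assay, compound 4 is expected to stay near or at the limit, and no direction can be read from the data. This expectation rests on compound 2, which gives only the limit > 5000 nM, and on compound 3, which gives only the limit > 5000 nM. The expected step is a step that the limit leaves unreadable from compound 3 to compound 4. For compound 4 the estimated value is 6000 nM, with an expected range of 2000 nM to 15000 nM.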

Compound 4, half-maximal inhibitory concentration: > 5000 nM
Compound 4 ended at the assay's limit; the forecaster's own chance of this, stated with the estimate: 75%; the middle value lies beyond the limit too.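

In this assay compound 4 gives only a limit, > 5000 nM, and no number. With 3-fluoro-4-methoxyphenyl on the sulfonyl sulfur, which carries no nitro group or trifluoromethyl group, the steps among the sulfonyl compounds still cannot be read, and this set remains defined by: the limit of > 5000 nM in this assay, at which 3 of the 4 values shown sit.

Exchange of ethylcarbamoyl for (3-fluoro-4-methoxyphenyl)sulfonyl on a nitrogen on an aromatic ring gives an at least 160-fold higher number from compound 1 to compound 4 (2.21 log units; beyond the scatter), the only readable step shown for a sulfonyl compound, and that size is a minimum.

From the compounds shown here alone, how far the sulfonyl compounds lie beyond the limit, and whether they differ from one another there, stays open. Also open, going by these compounds, is whether a simple methyl group or a morpholine on the sulfonyl sulfur, or a propylcarbamoyl group in place of ethylcarbamoyl, would give a number in this assay.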